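The source may report more compounds than this note shows. Statements on the series, on what has been measured and on what is new or still open speak of the compounds shown alone.

Of the compounds shown here, two sharing a core have been measured so far in an ADME assay on BHK-21 cells (Mesocricetus auratus) for cytotoxicity, read by MTT assay, with a stated time of 72 h (on this read-out lower numbers stand for higher toxicity in this test and higher numbers for lower toxicity in this test), as a guide to how much they harm cells. In this test compound 1 (`NS(=O)(=O)c1ccc(N2N=C(c3ccc(OCc4ccccc4)cc3)CC2c2ccc(F)cc2)cc1`) gives 60000 nM as its result, and compound 2 (`NS(=O)(=O)c1ccc(N2N=C(c3ccc(Oc4ccccc4)cc3)CC2c2cccc(Cl)c2)cc1`) gives 9000 nM as its result. Compound 2 therefore holds the lower of the two numbers, and the gap between them lies beyond the usual scatter of repeated measurements.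

The next compound, compound 3 (`NS(=O)(=O)c1ccc(N2N=C(c3ccc(OCc4ccccc4)cc3)CC2c2cccc(Cl)c2)cc1`), differs from compound 2 in a single place. The change benzyl in place of phenyl on an oxygen on an aromatic ring puts benzyl in place of phenyl on an oxygen on an aromatic ring, so phenoxy becomes benzyloxy. Going by the values given here, no measured pair shows this change alone, so the evidence is thin. Compound 1 also carries benzyloxy, and its 60000 nM value is the only hint of direction. In this assay the expected change is a 2.7-fold higher number from compound 2 to compound 3 (0.43 log units; beyond the scatter) as a modest upward move, only a little beyond the scatter. Compound 3 is estimated at 24000 nM in this test, with a range from 7000 nM to 75000 nM expected.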

Compound 3, half-maximal cytotoxic concentration: 45000 nM
The estimate for compound 3 lay 1.9-fold (0.27 log units) below the measured number, and the stated range covers the measured number.
By their numbers in this assay, from the lowest: compound 2; then compounds 3 and 1 (each within the scatter of the next).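

Going by these compounds alone, this is the first pair in this assay that isolates benzyl in place of phenyl on an oxygen on an aromatic ring, and it gives a 5.0-fold higher number from compound 2 to compound 3 (0.70 log units; beyond the scatter). Within the data shown here, with the rest of the molecule held fixed, benzyloxy therefore goes with lower toxicity in this test than phenoxy, which the earlier compounds could only hint at since compound 1 and compound 2 differ in more than one place. The second pair keeps benzyloxy in place and puts 3-chlorophenyl in place of 4-fluorophenyl on a saturated ring carbon, giving a 1.3-fold lower number from compound 1 to compound 3 (0.12 log units; within the scatter), so this swap shows no readable difference here, and no measurement is at hand that would explain either step.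

On these data alone, each change rests on a single pair, so it remains open whether phenoxy to benzyloxy moves the number the same way when 4-fluorophenyl sits on the saturated ring carbon. As far as these compounds go, it is also open how a longer chain on the oxygen, such as phenylethyl, or a simple methyl there would read in this test.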